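A Fluoro for Methyl Exchange in an Antiproliferative Series

This account rests on a few compounds, and the source may have more. Where it says the series, first, only, none or still open, it means among the compounds named here.

In a functional assay on SGC-7901 cells (Homo sapiens) for antiproliferative activity, read by MTT assay, with a stated time of 72 h (a lower number here means a stronger inhibitor, a higher number a weaker inhibitor), compound 1 `COc1cc(-n2cnc3ccc(-c4ccc(C(C)=O)cc4)cc32)cc(OC)c1OC` gives 450 nM and compound 2 `COc1cc(-n2cnc3ccc(-c4cccc(C)c4)cc32)cc(OC)c1OC` gives 1240 nM, the higher of the two numbers and so the weaker inhibitor of the pair. Compound 3 `COc1cc(-n2cnc3ccc(-c4cccc(F)c4)cc32)cc(OC)c1OC` differs from compound 2 in one group: fluoro in place of methyl on an aromatic carbon, meta to a large group. Within the data shown here, the only measured step that bears on this, a 2.8-fold higher number from compound 1 to compound 2 (0.44 log units; beyond the scatter), is modest but beyond the scatter, and it exchanged 4-acetylphenyl for 3-methylphenyl. Among the measured compounds shown here, no measured compound carries fluoro, so that guide is indirect. A swap of one heavy atom for another is expected to move the number less than that step did, and the expected change is a 1.2-fold lower number from compound 2 to compound 3 (0.09 log units; within the scatter), probably within the scatter. For compound 3 the estimated value is 1000 nM, with an expected range of 450 nM to 2300 nM.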

Compound 3, half-maximal inhibitory concentration: 2490 nM
Compound 3: middle estimate off by 2.5-fold (0.40 log units), on the low side, and the stated range ends below it.
By their numbers in this assay, from the lowest: compound 1; then compounds 2 and 3 (each within the scatter of the next).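

In this assay, fluoro in place of methyl on an aromatic carbon, meta to a large group, gives a 2.0-fold higher number from compound 2 to compound 3 (0.30 log units; within the scatter), so this exchange does not separate the two groups at this position. The larger exchange of 4-acetylphenyl for 3-fluorophenyl gives a 5.5-fold higher number from compound 1 to compound 3 (0.74 log units; beyond the scatter), which, like the earlier step to 3-methylphenyl, lies beyond the scatter and leaves compound 1 with the lowest number of the three. No measurement here accounts for these results.

The compounds shown cannot tell whether the gap to compound 1 follows the acetyl group itself or its place on the ring, since group and place change together in both steps from compound 1. From the compounds shown here alone, it also remains open how an amine or a carboxylic acid would read on the same aromatic carbon that carries fluoro in compound 3.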